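Replacing the Hydroxy with Chloro on the Aryl Ketone

A few compounds are considered here, and "the series" means these few. Any claim that something is new, unique, unknown or untested is made for them only; others in the source may bear on it.

Measured so far:
compound 1, `COc1ccc(C(=O)/C=C/c2cc3ccccc3[nH]c2=O)cc1`: 33500 nM
compound 2, `O=C(/C=C/c1cc2ccccc2[nH]c1=O)c1ccc(O)cc1`: 6330 nM

For the measured compounds named here, in an ADME assay on RXF 393 cells (Homo sapiens) for cytotoxicity, read by sulforhodamine B assay, with a stated time of 24 h (on this read-out lower numbers stand for higher toxicity in this test and higher numbers for lower toxicity in this test), compound 2 holds the lower of the two numbers; the only measured step, a 5.3-fold lower number from compound 1 to compound 2 (0.72 log units; beyond the scatter), came from hydrogen in place of methyl on an oxygen on an aromatic ring. Compound 3, `O=C(/C=C/c1cc2ccccc2[nH]c1=O)c1ccc(Cl)cc1`, differs from compound 2 by chloro in place of hydroxy on an aromatic carbon. Going by the values given here, no measured step matches this change directly. Among the compounds with values here, the one step available shows the hydroxy form giving the lower number, so removing the hydroxy is expected to move compound 3 back toward compound 1, an upward step of about a 2.4-fold higher number from compound 2 to compound 3 (0.37 log units; beyond the scatter). Compound 3 is therefore estimated at 15000 nM, within 5000 nM to 45000 nM.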

Compound 3, concentration lethal to 50% of the cells: > 100000 nM
Compound 3 gave a limit, no number (the forecaster's own chance of this, stated with the estimate: 10%); at least 6.6-fold (0.82 log units) between middle value and limit.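

In this assay, compound 3 gives > 100000 nM, which is a limit of the assay and not a number. Chloro in place of hydroxy still gives an at least 15-fold higher number from compound 2 to compound 3 (1.19 log units; beyond the scatter), and chloro in place of methoxy gives an at least 2.9-fold higher number from compound 1 to compound 3 (0.47 log units; beyond the scatter). On this aromatic carbon, then, chloro stands on the less toxic side of both oxygen-bearing groups rather than near methoxy, so the group here can move the read-out a long way. From the compounds shown here alone, whether an amine or a carboxylic acid here would follow hydroxy or chloro stays open. Going by these compounds, how far compound 3 lies past its limit also stays open.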